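Moving the methyl on the sulfonyl aryl group

The compounds below may be only part of what the source reports. "The series", "measured", "known", "first", "only" and "open" are said of these compounds alone.

Measured so far in an assay on cells for inhibition of HSP60/HSP10 (Homo sapiens), with a stated time of 60 min; on this read-out lower numbers stand for stronger inhibition and higher numbers for weaker inhibition:
compound 1 `O=S(=O)(Nc1ccc2oc(-c3ccccc3)nc2c1)c1cccc(C(F)(F)F)c1` gives > 100000 nM, a limit of the assay.
compound 2 `O=S(=O)(Nc1ccc(-c2nc3ccccc3o2)cc1)c1ccc(Cl)s1` gives 31000 nM.
compound 3 `Cc1cccc(S(=O)(=O)Nc2ccc3oc(-c4ccccc4)nc3c2)c1` gives > 100000 nM, a limit of the assay.

Compound 3 thus stands at the limit of > 100000 nM in this assay, at which 2 of the 3 values shown sit, and its value is a limit rather than a number. Among the measured compounds shown here, the only measured step, a step that the two limits leave unreadable from compound 1 to compound 3, has both ends at limits and gives no readable size. Compound 4 `Cc1ccc(S(=O)(=O)Nc2ccc3oc(-c4ccccc4)nc3c2)cc1` differs from compound 3 by 4-methylphenyl in place of 3-methylphenyl on a sulfonyl sulfur. For the measured compounds named here, no measured step moves the methyl on the sulfonyl aryl group, so nothing seen here indicates a direction or size for this change. Since compound 3 sits at the limit, compound 4 is expected to stay there, with the expected step that the limit leaves unreadable from compound 3 to compound 4 no change beyond the scatter. The estimate for compound 4 is 150000 nM, within 50000 nM to 500000 nM.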

Compound 4, half-maximal inhibitory concentration: > 100000 nM
Compound 4: a limit, no number (the forecaster's own chance of this, stated with the estimate: 80%); the middle value is on the limit's open side.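

Compound 3 and compound 4 both sit at a limit in this assay, so no step between them can be read: the limit of > 100000 nM in this assay, at which 3 of the 4 values shown sit.

Left open is whether 4-methylphenyl in place of 3-methylphenyl on a sulfonyl sulfur changes inhibition at all.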